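The source may report more compounds than this note shows. Statements on the series, on what has been measured and on what is new or still open speak of the compounds shown alone.

Working notes on the guanidine series bearing the imidazolylpropyl chain.

Of the compounds shown here, two have numbers so far. Compound 1 `N=C(NCCCc1c[nH]cn1)NCCCC(c1ccc(F)cc1)c1ccccn1` in a functional assay on cardiac atrium for agonist activity at histamine H2 receptor (Cavia porcellus) (on this read-out higher numbers stand for larger maximal responses and lower numbers for smaller maximal responses), gives 0.9. Compound 2 `N=C(NCCCc1c[nH]cn1)NCCC(c1ccc(Cl)cc1)c1ccccn1` in this assay gives 1. For the measured compounds named here, of these two numbers compound 2 holds the higher one, with compound 1 as its only neighbour, and the gap between them lies within the scatter, so the two values show the same thing: both compounds reach close to the full response of the reference agonist. Going by the values given here, no step between measured compounds that differ in one place is available, so nothing in the measured set says how a change on the diaryl carbon moves the response.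

Compound 3 `N=C(NCCCc1c[nH]cn1)NCCC(c1ccccn1)c1ccccc1F` is the next compound for this assay. Relative to compound 2 the change is 2-fluorophenyl in place of 4-chlorophenyl on a saturated chain carbon bound to an aromatic carbon and a saturated chain carbon. The chain to the guanidine is unchanged, as is the pyridyl group on the same saturated chain carbon.

Given that compound 1 at 0.9 and compound 2 at 1 both reach close to the full response of the reference agonist, the expected step a number 0.10 lower from compound 2 to compound 3 (within the scatter) is none beyond the scatter. Compound 3 is estimated at 0.9, with a range from 0.7 to 1.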

Compound 3, intrinsic activity: the largest response reached, as a fraction of the reference agonist's: 1
Beside the measured number, compound 3's estimate is 0.10 below it; the measured number falls inside the stated range.
By their numbers in this assay, from the lowest: compounds 1, 2 and 3 (each within the scatter of the next).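

In this assay the series now has its first step in one place: 2-fluorophenyl in place of 4-chlorophenyl on a saturated chain carbon bound to an aromatic carbon and a saturated chain carbon gives no change at the digits printed from compound 2 to compound 3 (within the scatter). This shows that, with the chain to the guanidine and the pyridyl group held fixed, this position accepts either of these two halogen-bearing phenyl groups with the maximal response kept close to that of the reference agonist, which the earlier pair could not show since compounds 1 and 2 differ in more than one place. The swap alters both the halogen and its numbered place on the phenyl ring, and no measurement is at hand that explains why the response holds.

Still open, from the compounds shown here alone, is whether the response survives at this position with a larger change, such as a phenyl ring carrying an amine or a carboxylic acid in place of the halogen. Also open, going by these compounds, is how far the halogen and its place on the ring each count on their own, for which 4-fluorophenyl would be the connecting group.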